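A few compounds are considered here, and "the series" means these few. Any claim that something is new, unique, unknown or untested is made for them only; others in the source may bear on it.

Compound 2 `O=[N+]([O-])c1ccc(-c2nc3cc(C(F)(F)F)ccc3[nH]2)c([N+](=O)[O-])c1` stands at the low end of the three numbers measured in an ADME assay on BHK cells (Mesocricetus auratus) for cytotoxicity, read by MTT assay, with a stated time of 96 h; on this read-out lower numbers stand for higher toxicity in this test and higher numbers for lower toxicity in this test: compound 2 gives 8000 nM, the lowest of the set. Its closest neighbour is compound 1 `O=[N+]([O-])c1ccc(-c2nc3cc(C(F)(F)F)ccc3[nH]2)cc1`, which in this assay gives 18000 nM, while the furthest is compound 3 `Cn1c(-c2ccc(N)cc2)nc2cc(C(F)(F)F)ccc21`, which in this assay gives 85000 nM.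

The next step goes from compound 2 to compound 4 `O=[N+]([O-])c1ccc(-c2nc3ccccc3[nH]2)c([N+](=O)[O-])c1`, a change counted as hydrogen in place of trifluoromethyl on an aromatic carbon.

Among the measured compounds shown here, only one measured step exists, a 2.3-fold lower number from compound 1 to compound 2 (0.35 log units; beyond the scatter), and it concerns a different change, a nitro in place of hydrogen, not the trifluoromethyl that is removed here. Compound 3 differs from compound 2 in more than one place, so its value shows only where a distant relative sits, not the effect of this single change. For the measured compounds named here, no measured step therefore bears directly on the trifluoromethyl removal, and its size and direction remain open.

In the absence of any step that speaks to it, compound 4 is expected to land close to compound 2, the expected step of a 1.3-fold higher number from compound 2 to compound 4 (0.10 log units; within the scatter) lying within the scatter. Compound 4 is accordingly estimated at 10000 nM in this assay, with a range from 3500 nM to 30000 nM.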

Compound 4, half-maximal cytotoxic concentration: > 100000 nM
Compound 4: only a limit was reported; the forecaster's own chance of this, stated with the estimate: 5%; at least 10-fold (1.00 log units) between middle value and limit.
By their numbers in this assay, from the lowest: compound 2; then compound 1; then compound 3. At a limit, above all of these: compound 4.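

In this assay, hydrogen in place of trifluoromethyl on the aromatic carbon of the fused system gives an at least 12-fold higher number from compound 2 to compound 4 (1.09 log units; beyond the scatter), a large step that shows this position is far from neutral for the number read here. Among the compounds shown here, the only earlier single change, a 2.3-fold lower number from compound 1 to compound 2 (0.35 log units; beyond the scatter), was modest and concerned a nitro group elsewhere in the molecule, so it gave no sign that a change at the trifluoromethyl position could weigh so much more heavily. Compound 4 is reported only as a limit, so the step gives a minimum size and not an exact one: the limit of > 100000 nM in this assay, at which 1 of the 4 values shown sits.

The compounds shown leave open whether removing trifluoromethyl has a similar effect when only one nitro group is present, as in compound 1, since every measured comparison at this position carries both nitro groups. They also leave open whether the large step depends on trifluoromethyl itself or would also appear with another group at this carbon, such as a chlorine atom, a methyl group, a methoxy group or a nitrile.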